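The compounds below may be only part of what the source reports. "The series", "measured", "known", "first", "only" and "open" are said of these compounds alone.

Measured compounds:
compound 1, `O=C(Nc1cccc(-n2cc(-c3ccncc3)c(-c3ccc(Cl)c(O)c3)n2)c1)Nc1cccc(C(F)(F)F)c1`: 7830 nM
compound 2, `COc1cc(-c2nn(-c3cccc(NC(=O)c4cccc(C(F)(F)F)c4)c3)cc2-c2ccncc2)ccc1Cl`: 4560 nM
compound 3, `COc1cc(-c2nn(-c3cccc(NC(=O)Nc4ccc(Cl)c(Cl)c4)c3)cc2-c2ccncc2)ccc1Cl`: 2270 nM

In a functional assay on MDA-MB-468 cells (Homo sapiens) for inhibition, read by sulforhodamine B assay, with a stated time of 48 h (on this read-out lower numbers stand for stronger inhibition of growth and higher numbers for weaker inhibition of growth), compound 3 gives the lowest of the three numbers. Its nearest neighbour is compound 2, which gives 4560 nM, a gap within the scatter, so the two cannot be ordered; compound 1 gives 7830 nM, a gap beyond the scatter. Among the measured compounds shown here, the one single-point step recorded, a 2.0-fold lower number from compound 2 to compound 3 (0.30 log units; within the scatter), concerns a different part of the molecule and so does not bear directly on what follows.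

Compound 4, `O=C(Nc1cccc(-n2cc(-c3ccncc3)c(-c3ccc(Cl)c(O)c3)n2)c1)Nc1ccc(Cl)c(Cl)c1`, has not yet been measured. It differs from compound 3 in one place: hydrogen in place of methyl on an oxygen on an aromatic ring. For the measured compounds named here, no measured pair isolates this change. Compound 1 carries the hydroxy group and compound 3 the methoxy group, but the two also differ elsewhere, so their values only hint that the hydroxy compound gave the higher number. On that thin basis a modest rise in this assay is expected, a 1.8-fold higher number from compound 3 to compound 4 (0.25 log units; within the scatter). Compound 4 is therefore estimated at 4000 nM, within a range of 1500 nM to 12000 nM.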

Compound 4, concentration for total growth inhibition: 4250 nM
The estimate for compound 4 lay 1.1-fold (0.03 log units) below the measured number; the range from low to high includes it.
By their numbers in this assay, from the lowest: compounds 3, 4, 2 and 1 (each within the scatter of the next, the first and the last beyond it).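

Among the compounds shown here, compound 3 and compound 4 form the first pair that isolates the swap of methoxy to hydroxy on the aromatic ring, and in this assay this swap gives a 1.9-fold higher number from compound 3 to compound 4 (0.27 log units; within the scatter) so the two compounds cannot be ordered. With the hydroxy group kept, putting 3,4-dichlorophenyl in place of 3-(trifluoromethyl)phenyl gives a 1.8-fold lower number from compound 1 to compound 4 (0.27 log units; within the scatter) so this pair cannot be ordered either, and neither single change can be told apart from ordinary assay scatter. Nothing available explains these numbers or links them to any property of the groups.

Still open, from the compounds shown here alone, is whether a longer chain on that oxygen, such as ethyl, or an acetyl group there would move the number beyond the scatter. An amine in place of the hydroxy group also remains untested among the compounds shown.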